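Bromo for nitro on the benzylsulfanyl arm

This account rests on a few compounds, and the source may have more. Where it says the series, first, only, none or still open, it means among the compounds named here.

Measured so far:
compound 1 `Cc1cc(Nc2ccc(C(=O)/C=C/c3ccc4ccccc4c3)cc2)n2nc(SCc3cccc(Br)c3)nc2n1` — 270 nM
compound 2 `Cc1cc(Nc2ccc(C(=O)/C=C/c3ccc4ccccc4c3)cc2)n2nc(SCc3cccc([N+](=O)[O-])c3)nc2n1` — 790 nM

In a functional assay on SW-620 cells (Homo sapiens) for cytotoxicity, read by MTT assay, with stated times of 4 h and 72 h, tested at 5 uM (on this read-out higher numbers stand for weaker inhibition and lower numbers for stronger inhibition), compound 2 gives 790 nM, the highest of the two numbers; its nearest neighbour, compound 1, gives 270 nM, and the step of a 2.9-fold higher number from compound 1 to compound 2 (0.47 log units; beyond the scatter). Compound 3 `Cc1cc(Nc2ccc(C(=O)/C=C/c3ccc4ccccc4c3)cc2)n2nc(SCc3ccccc3Br)nc2n1` is still unmeasured; it differs from compound 2 by 2-bromophenyl in place of 3-nitrophenyl on a saturated chain carbon bound to a sulfur. Among the measured compounds shown here, only the step from compound 1 to compound 2 bears on this, and only in part: it covers the exchange of nitro for bromo but not the shift to 2-bromophenyl, for which no measured step exists. Reversing that step suggests a lower number. Compound 3 is expected at 330 nM (range 130 nM to 900 nM), a step of a 2.4-fold lower number from compound 2 to compound 3 (0.38 log units; beyond the scatter) expected, with the shift to 2-bromophenyl widening the range.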

Compound 3, half-maximal inhibitory concentration: 420 nM
Compound 3: the middle estimate sits 1.3-fold (0.10 log units) below what was measured, within the range that was stated.
By their numbers in this assay, from the lowest: compounds 1, 3 and 2 (each within the scatter of the next, the first and the last beyond it).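

In this assay, 2-bromophenyl in place of 3-bromophenyl gives a 1.6-fold higher number from compound 1 to compound 3 (0.19 log units; within the scatter) on this arm, so the two bromophenyl groups cannot be told apart here. 2-bromophenyl in place of 3-nitrophenyl gives a 1.9-fold lower number from compound 2 to compound 3 (0.27 log units; within the scatter) and leaves compound 3 within the scatter of both neighbours, although compound 1 and compound 2 stand apart. No supporting evidence bears on this result.

Still open, going by these compounds, is how a plain benzyl, an amine or a carboxylic acid on the benzyl ring would compare with the bromo and nitro groups on this arm.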